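The source may report more compounds than this note shows. Statements on the series, on what has been measured and on what is new or still open speak of the compounds shown alone.

Working notes on the series. Compound 1 `OC[C@@H](O[C@H]1CCCN(Cc2ncc[nH]2)[C@H]1c1ccccc1)c1cc(Cl)cc(Cl)c1` gives 7000 nM in an assay on isolated protein for activation of cGMP-dependent protein kinase 1 (Homo sapiens), read by ADP-Glo, with stated times of 120 min and 40 min; a lower number here means that less compound is needed, a higher number that more compound is needed for the effect. Compound 2 `O=C(O)c1ccc(CN2CCC[C@H](O[C@H](CO)c3cc(Cl)cc(Cl)c3)[C@@H]2c2ccccc2)cc1` gives 11000 nM in this assay, and compound 3 `O=C(O)c1ccc2c(CN3CCC[C@H](O[C@H](CO)c4cc(Cl)cc(Cl)c4)[C@@H]3c3ccccc3)c[nH]c2c1` gives 22000 nM. Of these three numbers compound 3 stands highest, its gap to compound 2 within the scatter a 2.0-fold higher number from compound 2 to compound 3 (0.30 log units; within the scatter) and the other gap beyond it a 3.1-fold higher number from compound 1 to compound 3 (0.50 log units; beyond the scatter). Compound 4 `OC[C@@H](O[C@H]1CCCN(Cc2ccccc2Cc2nnco2)[C@H]1c1ccccc1)c1cc(Cl)cc(Cl)c1` differs from compound 3 by a group of 12 heavy atoms (9 carbon, 2 nitrogen, 1 oxygen; one five-membered aromatic ring with 3 hetero atoms, one six-membered aromatic ring of carbon only) in place of a group of 12 heavy atoms (9 carbon, 1 nitrogen, 2 oxygen; one five-membered aromatic ring with 1 hetero atom, one six-membered aromatic ring of carbon only), on a saturated chain carbon bound to an amine nitrogen in a ring. All measured steps sit at this same place and were small to modest, including a 1.6-fold higher number from compound 1 to compound 2 (0.20 log units; within the scatter). Compound 4 is therefore expected to shift only a little in this assay, if anything toward a lower number, an estimated 1.8-fold lower number from compound 3 to compound 4 (0.26 log units; within the scatter). Compound 4 is estimated at 12000 nM, with a range from 3500 nM to 40000 nM.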

Compound 4, half-maximal effective concentration: 3700 nM
For compound 4 the middle estimate is 3.2-fold (0.51 log units) above the measured one; low and high end bracket the measured number.
By their numbers in this assay, from the lowest: compounds 4, 1, 2 and 3 (each within the scatter of the next, the first and the last beyond it).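

The group entering in compound 4 carries no carboxy group and gives the first clear move toward a lower number at this place in this assay, with a 5.9-fold lower number from compound 3 to compound 4 (0.77 log units; beyond the scatter) and with a 3.0-fold lower number from compound 2 to compound 4 (0.47 log units; beyond the scatter) as well. Against the much smaller 1H-imidazol-2-yl there is a 1.9-fold lower number from compound 1 to compound 4 (0.28 log units; within the scatter), so a group of this size is accepted on this saturated chain carbon without a separable gain. Nothing at hand explains these steps.
Still open, on these data alone, is whether a primary amide or an amine in place of the five-membered aromatic ring with 3 hetero atoms would hold the number in this assay, and how much that ring contributes at all.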